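A few compounds are considered here, and "the series" means these few. Any claim that something is new, unique, unknown or untested is made for them only; others in the source may bear on it.

Values measured in a physicochemical assay for solubility, at pH 7.4 (a lower number here means a less soluble compound, a higher number a more soluble compound), so far:
Compound 1 `C[C@H]1[C@H](N)CN1c1nc2c(cc1F)c(=O)c(C(=O)O)cn2C1CC1` gives 16.5 ug/mL
Compound 2 `C[C@H](N)C(=O)N[C@@H](C)C(=O)N[C@@H]1CN(c2nc3c(cc2F)c(=O)c(C(=O)O)cn3C2CC2)[C@H]1C` gives > 500 ug/mL (a limit)
Compound 3 `C[C@@H]1[C@@H](NC(=O)[C@@H](C)N)CN1c1nc2c(cc1F)c(=O)c(C(=O)O)cn2C1CC1` gives > 500 ug/mL (a limit)

Compound 3 stands at the limit of > 500 ug/mL in this assay, at which 2 of the 3 values shown sit, and has no exact number. In compound 4 `C[C@@H](N)C(=O)N[C@@H]1CN(c2nc3c(cc2F)c(=O)c(C(=O)O)cn3C2CC2)[C@H]1C` the change is the two compounds have the same atoms and bonds and differ only in configuration as drawn: 2 of 3 stereo elements differ; a stereocentre at a saturated ring carbon is drawn S in compound 3 and R in compound 4; a stereocentre at a saturated ring carbon is drawn R in compound 3 and S in compound 4 and no atom or bond is different. Among the measured compounds shown here, the one measured step of an at least 30-fold higher number from compound 1 to compound 2 (1.48 log units; beyond the scatter) is large, but it adds a group on an amine nitrogen and gives no size for a change of configuration. No change beyond the scatter is therefore expected in this assay and no direction can be given. The expected step is a step that the limit leaves unreadable from compound 3 to compound 4 on this estimate. Compound 4 is estimated at 600 ug/mL with an expected range from 200 ug/mL to 1500 ug/mL and may again report only a limit.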

Compound 4, solubility: 386 ug/mL
Estimate against measurement, compound 4: 1.6-fold (0.19 log units) above; the measured number falls inside the stated range.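

In this assay, among the compounds shown here, compound 4 gives the first exact number for this amine nitrogen carrying a single (1-aminoethyl)carbonyl group, and that one group already accounts for a 23-fold higher number from compound 1 to compound 4 (1.37 log units; beyond the scatter). The other two steps are only floors, an at least 1.2-fold lower number from compound 3 to compound 4 (0.11 log units; that floor lies within the scatter) and an at least 1.2-fold lower number from compound 2 to compound 4 (0.11 log units; that floor lies within the scatter), so neither the swapped ring configuration nor the extra amino acid unit has a readable size: the limit of > 500 ug/mL in this assay, at which 2 of the 4 values shown sit.

From the compounds shown here alone, whether the ring configuration changes this read-out at all remains open. Also open, going by these compounds, is whether an acetyl group, which carries no amine of its own, would give a similar step on this nitrogen.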